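Replacing (dimethylamino)methyl with dimethylcarbamoyl on compound 2

A few compounds are considered here, and "the series" means these few. Any claim that something is new, unique, unknown or untested is made for them only; others in the source may bear on it.

Compound 2 (`Cc1nc(CN(C)C)ccc1-c1cnc(NCc2c(F)ccc3c2CCO3)c2cn[nH]c(=O)c12`) gives > 1000000 nM in a physicochemical assay for solubility, read by LC-MS, in phosphate buffer, with a stated time of 24 h, at pH 7.4 (on this read-out lower numbers stand for lower solubility and higher numbers for higher solubility), which is a limit of the assay and not a number. Compound 1 (`O=C1CCCN1c1cnc(NCc2c(F)ccc3c2CCO3)c2cn[nH]c(=O)c12`) gives < 2000 nM, which is also a limit. Compound 3 (`CNC(=O)c1ncc(-c2cnc(NCc3c(F)ccc4c3CCO4)c3cn[nH]c(=O)c23)n1C`) gives 5000 nM. Compound 4 (`Cc1nc(C(=O)N(C)C)ccc1-c1cnc(NCc2c(F)ccc3c2CCO3)c2cn[nH]c(=O)c12`) carries dimethylcarbamoyl in place of (dimethylamino)methyl on an aromatic carbon. The closest evidence is a large step, an at least 200-fold lower number from compound 2 to compound 3 (2.30 log units; beyond the scatter). Another large step is an at least 500-fold higher number from compound 1 to compound 2 (2.69 log units; beyond the scatter), and a smaller one is an at least 2.5-fold higher number from compound 1 to compound 3 (0.39 log units; beyond the scatter). Compound 3 also carries a carbamoyl group, and it reaches only 5000 nM, so a large step to a lower number in this assay is expected: an at least 50-fold lower number from compound 2 to compound 4 (1.69 log units; beyond the scatter). The estimate for compound 4 is 20000 nM, with an expected range from 4000 nM to 100000 nM.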

Compound 4, solubility: 403000 nM
The estimate for compound 4 lay 20-fold (1.30 log units) below the measured number, outside the stated range (above it).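

Putting dimethylcarbamoyl in place of (dimethylamino)methyl at this position gives an at least 2.4-fold lower number from compound 2 to compound 4 (0.39 log units; beyond the scatter) in this assay. Compound 2 stands at a limit of the assay and not at a number, so the full size of this step stays unknown: the limit of > 1000000 nM in this assay, at which 1 of the 4 values shown sits.

On this ring, compound 4 keeps a high number with its carbonyl group, so a carbamoyl group does not by itself bring the number down to that of compound 3, 5000 nM.

Still open, as far as these compounds go, is how a carboxylic acid or a longer amine chain would read at this position. Also open, from the compounds shown here alone, is whether the result depends on the methyl group that lies meta to it.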